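The source may report more compounds than this note shows. Statements on the series, on what has been measured and on what is new or still open speak of the compounds shown alone.

Among the three compounds measured in an assay on microsomes from liver for inhibition of 3-hydroxy-3-methylglutaryl-coenzyme A reductase (Rattus norvegicus) (a lower number here means a stronger inhibitor, a higher number a weaker inhibitor), compound 3 `O=C(O)C[C@H](O)C[C@H](O)CCn1c(C(F)(F)F)nc(-c2ccc(C(F)(F)F)cc2)c1-c1ccc(F)cc1` stands highest, at 200 nM; compound 2 `O=C(O)C[C@H](O)C[C@H](O)CCn1c(C(F)(F)F)nc(-c2ccc(F)cc2)c1-c1ccc(F)cc1` gives 38 nM and compound 1 `Cc1cccc(-c2nc(C(F)(F)F)n(CC[C@@H](O)C[C@@H](O)CC(=O)O)c2-c2ccc(F)cc2)c1` gives 29 nM. Compound 4 `Cc1cc(C)cc(-c2nc(C(F)(F)F)n(CC[C@@H](O)C[C@@H](O)CC(=O)O)c2-c2ccc(F)cc2)c1` differs from compound 3 in one place: 3,5-dimethylphenyl in place of 4-(trifluoromethyl)phenyl on an aromatic carbon. Going by the values given here, two measured steps bear on this change. The step of a 6.9-fold higher number from compound 1 to compound 3 (0.84 log units; beyond the scatter) and the step of a 5.3-fold higher number from compound 2 to compound 3 (0.72 log units; beyond the scatter) both went beyond the scatter toward weaker inhibition. Compound 4 undoes the change seen in a 6.9-fold higher number from compound 1 to compound 3 (0.84 log units; beyond the scatter) while adding a second methyl, for which no step is shown, so a return toward a lower number in this assay is expected. Compound 4 is therefore estimated at 30 nM, with a range from 12 nM to 80 nM. The expected step is a 6.7-fold lower number from compound 3 to compound 4 (0.82 log units; beyond the scatter).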

Compound 4, half-maximal inhibitory concentration: 24 nM
The estimate for compound 4 lay 1.3-fold (0.10 log units) above the measured number; the range from low to high includes it.
By their numbers in this assay, from the lowest: compounds 4, 1 and 2 (each within the scatter of the next); then compound 3.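

The step of a 1.2-fold lower number from compound 1 to compound 4 (0.08 log units; within the scatter) lies within the scatter, so in this assay a second methyl on the ring is accommodated without a readable change. Going by these compounds alone, the step of a 1.6-fold lower number from compound 2 to compound 4 (0.20 log units; within the scatter) also lies within the scatter, while the step of an 8.3-fold lower number from compound 3 to compound 4 (0.92 log units; beyond the scatter) lies beyond it, leaving 4-(trifluoromethyl)phenyl as the only group here set apart from the others. No evidence is given on what lies behind this difference. As far as these compounds go, whether a methoxy group or an amine on this aromatic ring would stay with compound 4 or with compound 3 remains open.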